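Swapping the aryl substituent on a pyrazole carboxylic acid

The source may hold more compounds than are shown below. What is called first, only, known or untested is meant among the compounds shown, and "the series" means these compounds.

Measured compounds:
compound 1, `Cc1nn(-c2nc(-c3ccc(Cl)c(Cl)c3)c(SC(C)C)s2)c(C(=O)O)c1-c1cncnc1`, 22000 nM
compound 2, `CCSc1sc(-n2nc(C)c(Cc3ccccc3[N+](=O)[O-])c2C(=O)O)nc1-c1ccc(Cl)c(Cl)c1`, 59000 nM
compound 3, `Cc1nn(-c2nc(-c3ccc(Cl)c(Cl)c3)c(SC(C)C)s2)c(C(=O)O)c1-c1cncc(C#N)c1`, 20000 nM

In a functional assay on BJAB cells (Homo sapiens) for antiproliferative activity, with a stated time of 4 days (on this read-out higher numbers stand for an effect only at larger amounts of compound and lower numbers for an effect already at smaller amounts), compound 3 gives the lowest of the three numbers. Its nearest neighbour is compound 1, and the step of a 1.1-fold lower number from compound 1 to compound 3 (0.04 log units; within the scatter) lies within the scatter, so the two cannot be ordered. Compound 2 stands furthest away, and its value is beyond the scatter from that of compound 3.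

Compound 4, `CNc1cc(-c2c(C)nn(-c3nc(-c4ccc(Cl)c(Cl)c4)c(SC(C)C)s3)c2C(=O)O)ccn1`, has not yet been measured in this assay. It differs from compound 3 by 2-(methylamino)pyridin-4-yl in place of 5-cyanopyridin-3-yl on an aromatic carbon.

Within the data shown here, the only measured step that bears on this change is the one from compound 1 to compound 3, in which the group at the same place of the shared core was exchanged; that step, a 1.1-fold lower number from compound 1 to compound 3 (0.04 log units; within the scatter), was within the scatter. Among the measured compounds shown here, there is no measured step that speaks to a 2-(methylamino)pyridin-4-yl group, so the expectation rests on the one exchange seen so far. Compound 4 is therefore expected to show no step beyond the scatter in this assay, with no change at the digits printed from compound 3 to compound 4 (within the scatter) as the estimated change.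

Compound 4 is estimated at 20000 nM, with a range from 8000 nM to 50000 nM.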

Compound 4, half-maximal effective concentration: 18000 nM
For compound 4 the middle estimate is 1.1-fold (0.05 log units) above the measured one, and the stated range covers the measured number.
By their numbers in this assay, from the lowest: compounds 4, 3 and 1 (each within the scatter of the next); then compound 2.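

In this assay the exchange of 5-cyanopyridin-3-yl for 2-(methylamino)pyridin-4-yl gives a 1.1-fold lower number from compound 3 to compound 4 (0.05 log units; within the scatter) and the exchange of pyrimidin-5-yl for the same group gives a 1.2-fold lower number from compound 1 to compound 4 (0.09 log units; within the scatter) and so both steps stay within the scatter, leaving the three compounds unordered. The group that leaves compound 3 has a triple bond and 0 hydrogen-bond donors, while the group that enters compound 4 has no triple bond and 1 hydrogen-bond donor, so at this place on an aromatic carbon these differences in the substituent go with no readable change in the number. No measurement at hand offers an explanation for this flat result.

The compounds shown leave open whether any group at this place can move the number beyond the scatter, for instance a plain phenyl ring, an open-chain amine or a longer alkyl chain. They also leave open whether the same exchanges would stay as flat with a methyl ester or an amide in place of the carboxy group on the neighbouring ring atom.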